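Side-chain exchange on the shared core: from compound 1 to compound 4

The source may hold more compounds than are shown below. What is called first, only, known or untested is meant among the compounds shown, and "the series" means these compounds.

Measured so far:
compound 1 `CN(C)CCCCCn1c2c(c3ccccc31)C(=O)c1c[n+]([O-])c3ccccc3c1C2=O`: 370 nM
compound 2 `CC1(C)OC[C@H](Cn2cc(Cn3c4c(c5ccccc53)C(=O)c3c[n+]([O-])c5ccccc5c3C4=O)nn2)O1`: 820 nM
compound 3 `O=C1c2c[n+]([O-])c3ccccc3c2C(=O)c2c1c1ccccc1n2Cc1cn([C@@H]2O[C@H](CO)[C@@H](O)[C@H](O)[C@H]2O)nn1`: 880 nM

In a functional assay on SH-SY5Y cells (Homo sapiens) for cytotoxicity, read by MTT assay, with a stated time of 72 h (on this read-out lower numbers stand for stronger inhibition and higher numbers for weaker inhibition), compound 1 gives the lowest of the three numbers, and its gaps to compound 2 and to compound 3 both lie beyond the scatter. Compound 4 `O=C1c2c[n+]([O-])c3ccccc3c2C(=O)c2c1c1ccccc1n2Cc1cn(C[C@@H](O)CO)nn1` is not yet measured. It differs from compound 1 by 1-(2,3-dihydroxypropyl)-1H-1,2,3-triazol-4-yl in place of 4-(dimethylamino)butyl on a saturated chain carbon bound to an aromatic nitrogen. Going by the values given here, the only measured step of one change, a 1.1-fold higher number from compound 2 to compound 3 (0.03 log units; within the scatter), exchanges the group on the triazole nitrogen and stays within the scatter; no measured step covers the exchange of the dimethylaminobutyl chain itself, but compound 2 and compound 3, which also carry a triazole in place of that chain, give higher numbers than compound 1. Compound 4 is therefore expected to sit near them, with a 2.2-fold higher number from compound 1 to compound 4 (0.33 log units; beyond the scatter) as the expected step, estimated at 800 nM (range 400 nM to 1600 nM).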

Compound 4, half-maximal inhibitory concentration: > 500 nM
Compound 4: a limit, no number; the forecaster's own chance of this, stated with the estimate: 3%; the middle value is on the limit's open side.
By their numbers in this assay, from the lowest: compound 1; then compounds 2 and 3 (each within the scatter of the next).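

In this assay compound 4 gives > 500 nM, a limit of the assay and not a number. Going by these compounds alone, this is the first one-place exchange of the 4-(dimethylamino)butyl group, and it gives an at least 1.3-fold higher number from compound 1 to compound 4 (0.13 log units; that floor lies within the scatter), so only a floor is read and it does not establish a real change at this position. The steps to compound 4 from compound 2 and from compound 3 cannot be read.

The compounds shown do not separate loss of the dimethylamino group from entry of the triazole. A triazole carrying a dimethylaminoethyl group on its nitrogen would test this.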